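From Methylfuran to Thiophene on the Shared Core

The compounds below may be only part of what the source reports. "The series", "measured", "known", "first", "only" and "open" are said of these compounds alone.

Compound 1, `Cc1ccc(-c2nc(N)c3cc(CN4CCCC4)sc3n2)o1`: 620 nM
Compound 2, `Cc1ccc(-c2nc(N)c3cc(CN4CCCCC4)sc3n2)o1`: 610 nM
Compound 3, `Nc1nc(-c2ccc(C(F)F)o2)nc2sc(CN3CCC(F)(F)CC3)cc12`: 17800 nM

Of the compounds shown here, three have been measured in an assay on CHO-K1 cells for antagonist activity at adenosine receptor A1 (Homo sapiens), read by a beta-galactosidase reporter, with stated times of 15 min and 6 h; a lower number here means a stronger inhibitor, a higher number a weaker inhibitor. Compound 1 stands second highest of the three numbers; compound 2 sits closest to it, and compound 3 lies furthest away, with a number well beyond the scatter from that of compound 1. For the measured compounds named here, the one step between compounds that differ in a single place, a 1.0-fold lower number from compound 1 to compound 2 (0.01 log units; within the scatter), concerns the amine on the saturated chain carbon and not the aromatic ring that is now in question.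

Compound 4, `Nc1nc(-c2cccs2)nc2sc(CN3CCCC3)cc12`, differs from compound 1 in that (thiophen-2-yl in place of 5-methylfuran-2-yl on an aromatic carbon). Going by the values given here, no measured pair shows this exchange on its own; compound 3 carries a different furan and a different amine at once, so its value cannot be set against compound 1 for this purpose. The data therefore give no direct guide to this change, and compound 4 is expected to give a number close to that of compound 1 in this assay, with a step, a 1.5-fold higher number from compound 1 to compound 4 (0.16 log units; within the scatter), that is estimated to stay near the scatter. The estimate for compound 4 is 900 nM, within a range from 300 nM to 3000 nM.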

Compound 4, inhibition constant: > 10000 nM
Compound 4: a limit, no number (the forecaster's own chance of this, stated with the estimate: 5%); middle value at least 11-fold (1.04 log units) from the limit.
By their numbers in this assay, from the lowest: compounds 2 and 1 (each within the scatter of the next); then compound 3.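

In this assay, for the compounds shown here, the only earlier step between compounds differing in one place, a 1.0-fold lower number from compound 1 to compound 2 (0.01 log units; within the scatter), concerned the amine and said nothing about the aromatic carbon between two ring nitrogen atoms. At that position, thiophen-2-yl in place of 5-methylfuran-2-yl gives an at least 16-fold higher number from compound 1 to compound 4 (1.20 log units; beyond the scatter), so this position is not indifferent to which five-membered aromatic ring it carries, even though each group has one ring hetero atom. The value of compound 4 is a limit of the assay and not a number: the limit of > 10000 nM in this assay, at which 1 of the 4 values shown sits.

This exchange changes the ring hetero atom from oxygen to sulfur and removes the methyl group at the same time, so the compounds shown cannot separate the two changes; plain furan-2-yl or 5-methylthiophen-2-yl at this position would be the groups to tell them apart. Going by these compounds, it also remains open whether the same exchange would have a similar effect with the piperidin-1-yl group of compound 2 in place of the pyrrolidin-1-yl group.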